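Branching the chain two bonds from the biaryl in compound 1

The source may report more compounds than this note shows. Statements on the series, on what has been measured and on what is new or still open speak of the compounds shown alone.

Two measured members of the series are on hand. In an in vitro functional assay on cells for agonist activity at Bombesin receptor subtype-3 (Mus musculus), read by luminescence and calcium flux (on this read-out higher numbers stand for an effect only at larger amounts of compound and lower numbers for an effect already at smaller amounts), compound 1, `CCCCc1cnc(C(C)Cc2ccc(-c3ccccc3C(=O)O)cc2)[nH]1`, gives 184 nM, the lowest of the two numbers. Compound 2, `COc1ccc(Cc2cnc(CCc3ccc(-c4ccccc4C(=O)O)cc3)[nH]2)cc1`, gives 513 nM in this assay, a higher number that lies beyond the scatter of the pair; the two compounds differ in more than one place, so the values show only where each stands, not what any single change does.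

Compound 3, `CCCCc1cnc(C(CC)Cc2ccc(-c3ccccc3C(=O)O)cc2)[nH]1`, has not yet been measured in this assay. It differs from compound 1 by methyl in place of hydrogen on a saturated chain carbon, two bonds along the chain from an aromatic carbon: in words, methyl in place of hydrogen on a saturated chain carbon, two bonds along the chain from an aromatic carbon. Going by the values given here, no measured pair isolates such a change, so there is nothing to read a direction from. The expectation is for a step from compound 1 to compound 3 of a 1.1-fold higher number from compound 1 to compound 3 (0.06 log units; within the scatter), that is, no step beyond the scatter in either direction. On that basis compound 3 is estimated at 210 nM in this assay, within a range of 70 nM to 650 nM.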

Compound 3, half-maximal effective concentration: 340 nM
The estimate for compound 3 lay 1.6-fold (0.21 log units) below the measured number, and the stated range covers the measured number.
By their numbers in this assay, from the lowest: compounds 1, 3 and 2 (each within the scatter of the next, the first and the last beyond it).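

Methyl to ethyl at this branch gives, in this assay, a 1.8-fold higher number from compound 1 to compound 3 (0.27 log units; within the scatter), and this is the first pair in the series to differ in one place only. At this saturated chain carbon, two bonds along the chain from an aromatic carbon, the one added carbon therefore produces no step beyond the scatter, so compounds 1 and 3 cannot be told apart on this read-out and the position accepts either the methyl or the ethyl branch. No measurement bears on why the step has this size, so the pair fixes its size and nothing about its origin.

This single step does not show whether the same holds for a longer or differently shaped branch, such as propyl, isopropyl or cyclopropyl, or for a branch that carries a hydroxyl group or an amine. It also leaves open what the methyl branch of compound 1 contributes on its own, since a one-place comparison with hydrogen at this carbon is absent from the compounds shown.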